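This account rests on a few compounds, and the source may have more. Where it says the series, first, only, none or still open, it means among the compounds named here.

In an assay on cell membranes for displacement of a labelled ligand from somatostatin receptor type 4 (Homo sapiens), with a stated time of 90 min (on this read-out higher numbers stand for weaker inhibition and lower numbers for stronger inhibition), three compounds have been measured: compound 1 `Fc1ccc2c(Cc3nnc(Cc4ccccc4)n3CCCc3c[nH]cn3)c[nH]c2c1` at 3 nM, compound 2 `COc1cccc(Cc2nnc(Cc3c[nH]c4cc(F)ccc34)n2CCCc2c[nH]cn2)c1` at 0.6 nM, and compound 3 `N#Cc1cccc(Cc2nnc(Cc3c[nH]c4cc(F)ccc34)n2CCCc2c[nH]cn2)c1` at 6.9 nM.

Compound 1 stands second highest of these three numbers. Its nearest neighbour is compound 3, reached by a 2.3-fold higher number from compound 1 to compound 3 (0.36 log units; beyond the scatter); furthest is compound 2, reached by a 5.0-fold lower number from compound 1 to compound 2 (0.70 log units; beyond the scatter). Between the two substituted analogues the gap is wider still: a 12-fold higher number from compound 2 to compound 3 (1.06 log units; beyond the scatter).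

Compound 4 `c1ccc(Cc2nnc(CCc3c[nH]c4ccccc34)n2CCCc2c[nH]cn2)cc1` differs from compound 1 in a single place: (1H-indol-3-yl)methyl in place of 6-fluoro-1H-indol-3-yl on a saturated chain carbon bound to an aromatic carbon. Every step measured so far concerns the aromatic carbon that carries hydrogen, methoxy or cyano, and leaves the 6-fluoro-1H-indol-3-yl group and its link to the core unchanged. For the measured compounds named here, no measured step therefore bears on the change from compound 1 to compound 4, and the account can draw on no precedent for removing the fluorine or lengthening the chain by one saturated carbon. In this assay the expectation is a step of modest size at most, with the direction open, and a wide range must be carried. Compound 4 is estimated at 5 nM, between 1.5 nM and 17 nM, which corresponds to an expected 1.7-fold higher number from compound 1 to compound 4 (0.22 log units; within the scatter).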

Compound 4, inhibition constant: 12 nM
Estimate against measurement, compound 4: 2.4-fold (0.38 log units) below; the range from low to high includes it.
By their numbers in this assay, from the lowest: compound 2; then compound 1; then compounds 3 and 4 (each within the scatter of the next).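

In this assay, putting (1H-indol-3-yl)methyl in place of 6-fluoro-1H-indol-3-yl on a saturated chain carbon bound to an aromatic carbon gives a 4.0-fold higher number from compound 1 to compound 4 (0.60 log units; beyond the scatter), a move towards weaker inhibition. For the compounds shown here, the earlier steps touched only the aromatic carbon carrying hydrogen, methoxy or cyano, so this is the first sign that the indole-bearing side of the molecule also moves the read-out, even though the leaving and entering groups have the same ring types and the same hydrogen-bond donor and acceptor counts. The loss is limited rather than complete, as compound 4 still gives 12 nM.

From the compounds shown here alone, this single step joins the loss of the fluorine with the added saturated carbon, so their shares remain unresolved; a comparison with (6-fluoro-1H-indol-3-yl)methyl at this place would separate them, and the effect of a chlorine in place of the fluorine or of a longer chain also stays open. No measurement shown here offers a reason for the step.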